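Amide-to-amine step on the sugar-like ring of compound 1

The source may hold more compounds than are shown below. What is called first, only, known or untested is meant among the compounds shown, and "the series" means these compounds.

Compound 1 `CO[C@@H]1[C@H](N(C)C(C)=O)C[C@H]2O[C@]1(C)n1c3ccccc3c3c4c(c5c6ccccc6n2c5c31)C(=O)NC4=O` gives 50 nM in an assay on isolated protein for inhibition of protein kinase C theta type (Homo sapiens), read by HTRF; a lower number here means a stronger inhibitor, a higher number a weaker inhibitor. Two further compounds of the series have been measured. Compound 3 `C[C@]12O[C@H](C[C@@H](O)[C@H]1O)n1c3ccccc3c3c4c(c5c6ccccc6n2c5c31)CNC4=O` gives 600 nM in this assay, and compound 2 `CO[C@@H]1[C@@H](O)[C@@H](O)[C@H]2O[C@]1(C)n1c3ccccc3c3c4c(c5c6ccccc6n2c5c31)C(=O)NC4` gives 1010 nM in this assay. Compound 1 therefore holds the lowest number of the three, and its gaps to compound 3 and to compound 2 both lie beyond the scatter, so it is the strongest inhibitor measured so far. Among the compounds with values here, compounds 2 and 3 each differ from compound 1 in more than one place, so no single-change step between measured compounds is available to calibrate against.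

Compound 4 `CO[C@@H]1[C@H](N)C[C@H]2O[C@]1(C)n1c3ccccc3c3c4c(c5c6ccccc6n2c5c31)C(=O)NC4=O` has not yet been measured. It differs from compound 1 in one place: amino in place of acetyl(methyl)amino on a saturated ring carbon. Within the data shown here, no measured pair isolates this change, and the measured compounds offer no direct guide to its size. The step from compound 1 to compound 4 is expected to be a 1.7-fold lower number from compound 1 to compound 4 (0.22 log units; within the scatter), which amounts to no change beyond the scatter or a modest move toward a lower number. Compound 4 is accordingly estimated at 30 nM, with a range from 8 nM to 120 nM.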

Compound 4, half-maximal inhibitory concentration: 36 nM
Estimate against measurement, compound 4: 1.2-fold (0.08 log units) below; low and high end bracket the measured number.
By their numbers in this assay, from the lowest: compounds 4 and 1 (each within the scatter of the next); then compounds 3 and 2 (each within the scatter of the next).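

Within the data shown here, replacing acetyl(methyl)amino with amino on this saturated ring carbon gives, in this assay, a 1.4-fold lower number from compound 1 to compound 4 (0.14 log units; within the scatter), the first single-change step. At this position, a group of 5 heavy atoms with no hydrogen-bond donor can therefore give way to a group of 1 heavy atom with 1 hydrogen-bond donor, and the number stays within the scatter, so the full acetyl(methyl)amino group is not required to keep compound 4 level with compound 1 in this assay. No measurement available here explains why the number holds across this change.

As far as these compounds go, because both the methyl and the acetyl part leave in this one step, their separate contributions remain open, and methylamino or acetylamino on the same carbon would be needed to tell them apart. Among these compounds, also open is how far this position accepts other groups, such as a longer alkyl chain or a carboxylic acid, since the only groups compared here are acetyl(methyl)amino and amino.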